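Lengthening the chain in a trityl-protected uracil

The compounds below may be only part of what the source reports. "The series", "measured", "known", "first", "only" and "open" are said of these compounds alone.

Two compounds have been characterised in an assay on isolated protein for inhibition of Deoxyuridine 5'-triphosphate nucleotidohydrolase, mitochondrial (Homo sapiens); a lower number here means a stronger inhibitor, a higher number a weaker inhibitor. Compound 1 `O=c1ccn(CCCOC(c2ccccc2)(c2ccccc2)c2ccccc2)c(=O)[nH]1` has the highest of the two numbers: in this assay compound 1 gives 313000 nM. Among the measured compounds shown here, compound 2 `CC(C)(C)[Si](C)(C)OCCCn1ccc(=O)[nH]c1=O` gives 73000 nM in this assay, a lower number than compound 1 by a margin beyond the usual scatter; the two compounds differ in more than one place, so no single step can be drawn between them. Compound 3 `O=c1ccn(CCCCCCOC(c2ccccc2)(c2ccccc2)c2ccccc2)c(=O)[nH]1` has not yet been measured. It is derived from compound 1 by a change of a group of 11 heavy atoms (7 carbon, 2 nitrogen, 2 oxygen; one six-membered aromatic ring with 2 hetero atoms) in place of a group of 8 heavy atoms (4 carbon, 2 nitrogen, 2 oxygen; one six-membered aromatic ring with 2 hetero atoms), on a saturated chain carbon, three bonds along the chain from an oxygen on a saturated carbon. The shared core of compound 1 and compound 3 is the same, and the trityl ether is kept; only the chain between them is altered. For the measured compounds named here, no measured pair tells how such a chain change acts here, so the step from compound 1 to compound 3 is expected to be small, a 1.6-fold lower number from compound 1 to compound 3 (0.19 log units; within the scatter), in either direction or none beyond the scatter. For compound 3 the expected inhibition constant is 200000 nM, with a range from 50000 nM to 800000 nM.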

Compound 3, inhibition constant: 476000 nM
Estimate against measurement, compound 3: 2.4-fold (0.38 log units) below; low and high end bracket the measured number.
By their numbers in this assay, from the lowest: compound 2; then compounds 1 and 3 (each within the scatter of the next).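

In this assay, the group of 11 heavy atoms in place of the group of 8 heavy atoms, on a saturated chain carbon, three bonds along the chain from an oxygen on a saturated carbon, gives a 1.5-fold higher number from compound 1 to compound 3 (0.18 log units; within the scatter). Among the compounds shown here, this is the first single-place step, and it shows that, with the trityl ether kept, this change to the chain does not separate the two compounds beyond the usual scatter. No measurement available here bears on this result.

The compounds shown leave open whether a chain shorter than that of compound 1, or longer than that of compound 3, would shift the number beyond the scatter. They also leave open whether the same change would act alike with a free hydroxyl, a carboxylic acid or an amine at the chain end in place of the trityl ether.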